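A few compounds are considered here, and "the series" means these few. Any claim that something is new, unique, unknown or untested is made for them only; others in the source may bear on it.

Compound 1 `COc1cc(OC)c2sc(-c3ccc(N/C=C\C(=O)c4ccc(OC)c(O)c4)c(C)c3)nc2c1` gives 16100 nM
Compound 2 `COc1ccc(C(=O)/C=C\Nc2ccc(-c3nc4cc(OC)c(OC)c(OC)c4s3)cc2C)cc1O` gives 11400 nM
Compound 3 `COc1cc(OC)c2sc(-c3ccc(N/C=C\C(=O)c4ccc(OC)c([N+](=O)[O-])c4)c(C)c3)nc2c1` is not yet measured

Among the compounds with values here, in a functional assay on HeLa cells (Homo sapiens) for antiproliferative activity, read by sulforhodamine B assay, with a stated time of 48 h (a higher number here means a weaker inhibitor, a lower number a stronger inhibitor), only compound 1 and compound 2 have values so far, and the two lie within the scatter of each other. Compound 3 differs from compound 1 by nitro in place of hydroxy on an aromatic carbon, ortho to a methoxy group (nitro in place of hydroxy on an aromatic carbon), so that 3-hydroxy-4-methoxyphenyl becomes 4-methoxy-3-nitrophenyl. Within the data shown here, the sole measured step is a 1.4-fold lower number from compound 1 to compound 2 (0.15 log units; within the scatter), and it is a methoxy in place of hydrogen in a different part of the molecule. Among the measured compounds shown here, no measured step touches the hydroxy, so neither size nor direction is directly supported, and the range stays wide. The expectation for compound 3 is a 1.2-fold lower number from compound 1 to compound 3 (0.06 log units; within the scatter), with no shift beyond the scatter. The estimated value for compound 3 is 14000 nM, within an expected range of 5000 nM to 40000 nM for the coming measurement.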

Compound 3, half-maximal inhibitory concentration: 9390 nM
Compound 3: middle estimate off by 1.5-fold (0.17 log units), on the high side; the range from low to high includes it.
By their numbers in this assay, from the lowest: compounds 3, 2 and 1 (each within the scatter of the next).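

In this assay the only change shown at this position, 3-hydroxy-4-methoxyphenyl to 4-methoxy-3-nitrophenyl, gives a 1.7-fold lower number from compound 1 to compound 3 (0.23 log units; within the scatter) on an aromatic carbon ortho to a methoxy group. Compound 3 has no hydrogen-bond donor in this group and a larger substituent than compound 1, yet the two cannot be told apart here, so a number in this range does not depend on the hydroxy in this pair. No measurement bears on what lies behind this result.

As far as these compounds go, whether an amine, a carboxylic acid or plain hydrogen at this position would shift the number beyond the scatter remains open. Also open, from the compounds shown here alone, is whether nitro in place of hydroxy reads the same on the core of compound 2.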